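The source may report more compounds than this note shows. Statements on the series, on what has been measured and on what is new or still open speak of the compounds shown alone.

In a functional assay on CCRF-CEM cells (Homo sapiens) for inhibition (a higher number here means a weaker inhibitor, a lower number a stronger inhibitor), compound 3 (`Cn1cc(C#N)c2ccc(Nc3ncc(-c4cccc(CNC(=O)c5cccc6ccccc56)c4)o3)cc21`) gives 2500 nM. Compound 2 (`Cn1cc(C#N)c2ccc(Nc3ncc(-c4cccc(CNC(=O)c5ccc6ccccc6c5)c4)o3)cc21`) gives 4400 nM, within the scatter of compound 3, while compound 1 (`Cn1cc(C#N)c2ccc(Nc3ncc(-c4ccccc4)o3)cc21`) gives 8000 nM, a clearly higher number than compound 3. Compound 4 (`Cn1cc(C#N)c2ccc(Nc3ncc(-c4cccc(CNC(=O)OC5CCOC5)c4)o3)cc21`) differs from compound 3 by (oxolan-3-yl)oxy in place of naphthalen-1-yl on a carbonyl carbon. Among the measured compounds shown here, only one measured step bears on this, a 1.8-fold lower number from compound 2 to compound 3 (0.25 log units; within the scatter), and it merely exchanges naphthalen-2-yl for naphthalen-1-yl. For the measured compounds named here, no measured compound shows this group on the carbonyl carbon, so the guidance is weak. In this assay the expected change is a 1.6-fold higher number from compound 3 to compound 4 (0.20 log units; within the scatter), a slightly higher number that stays within the scatter. For compound 4 the estimate is 4000 nM, with an expected range of 1300 nM to 12000 nM.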

Compound 4, half-maximal inhibitory concentration: > 10000 nM
Compound 4: only a limit was reported (the forecaster's own chance of this, stated with the estimate: 10%); middle value at least 2.5-fold (0.39 log units) away from the limit.
By their numbers in this assay, from the lowest: compounds 3, 2 and 1 (each within the scatter of the next, the first and the last beyond it). At a limit, above all of these: compound 4.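

In this assay compound 4 stands at a limit: the limit of > 10000 nM in this assay, at which 1 of the 4 values shown sits. On the carbonyl carbon, (oxolan-3-yl)oxy does not match either naphthalene group, giving an at least 4.0-fold higher number from compound 3 to compound 4 (0.60 log units; beyond the scatter) and an at least 2.2-fold higher number from compound 2 to compound 4 (0.35 log units; beyond the scatter), whereas the exchange between the two naphthalene groups had stayed within the scatter. Setting the whole side chain against hydrogen gives an at least 1.2-fold higher number from compound 1 to compound 4 (0.09 log units; that floor lies within the scatter), so that chain cannot be separated from hydrogen here. On these data alone, whether the ring system or the oxygen joined to the carbonyl carbon matters remains open. A phenyl group or a chain ending in an amine on that carbon could help to decide this.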